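Methoxy Gives Way to Iodo on a Fused Core

The source may hold more compounds than are shown below. What is called first, only, known or untested is meant among the compounds shown, and "the series" means these compounds.

The study measures activation in a functional assay (spleen, spleen) for activation, with Mus musculus as the target; a lower number here means that less compound is needed, a higher number that more compound is needed for the effect. Compound 1 `CCCCc1nc(N)c2nc(O)n(Cc3ccccc3)c2n1` gives 0.03 uM in this assay. Compound 3 `CCCCCNc1nc(N)c2nc(O)n(Cc3ccccc3)c2n1`, which carries pentylamino in place of butyl on an aromatic carbon, gives 0.1 uM, and the step of a 3.3-fold higher number from compound 1 to compound 3 (0.52 log units; beyond the scatter) is the only measured one. Compound 2 `COc1nc2c(N)ncnc2n1Cc1ccccc1` stands apart from both: in this assay compound 2 reaches only > 10 uM, which is a limit of the assay and not a number (the limit of > 10 uM in this assay, at which 1 of the 3 values shown sits). Compound 2 is thus the one of the three measured compounds for which no effect concentration is known.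

Compound 4 `Nc1ncnc2c1nc(I)n2Cc1ccccc1` is not yet measured. It differs from compound 2 in one place (iodo in place of methoxy on an aromatic carbon). The measured step from compound 1 to compound 3 concerns a different group at a different place and bears no direct evidence on exchanging methoxy for iodo, so no size of step can be read from it. With compound 2 sitting at the limit, the account can only expect that compound 4 stays in the same weak region unless the iodo substitution changes matters. Compound 4 is therefore estimated to give 10 uM in this assay, with a range from 1 uM to 30 uM. The step expected for a number no higher from compound 2 to compound 4 (the limit leaves the size open) is accordingly uncertain and measured against a limit.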

Compound 4, minimum effective concentration: > 10 uM
Compound 4 gave a limit, no number; the forecaster's own chance of this, stated with the estimate: 60%; the middle value sits exactly at the limit.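

In this assay compound 4 gives > 10 uM, which is a limit of the assay and not a number. Compound 2 also stands at a limit, so no step between compound 2 and compound 4 can be read: the limit of > 10 uM in this assay, at which 2 of the 4 values shown sit.

The compounds shown leave open where the effect concentrations of compound 2 and compound 4 lie, and whether iodo in place of methoxy changes anything in this assay.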